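The source may hold more compounds than are shown below. What is called first, only, known or untested is meant among the compounds shown, and "the series" means these compounds.

Of the compounds shown here, two from this series have been measured in an assay on C6 glioma cells for displacement of a labelled ligand from sodium- and chloride-dependent glycine transporter 1 (Rattus norvegicus), read by scintillation counting, with stated times of 30 min and 10 min; on this read-out lower numbers stand for stronger inhibition and higher numbers for weaker inhibition. Compound 1, `Cc1nnc(-c2ccc(-c3ccncc3)cc2)n1-c1ccccc1F`, gives 5900 nM in this assay. Compound 2, `CCc1nnc(-c2ccc(-c3ccccc3)cc2)n1-c1ccccc1C`, gives 300 nM in this assay, the lower of the two numbers shown. The two compounds differ at more than one position, so the comparison between them shows only the two values side by side and carries no single structural lesson.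

Compound 3, `CCc1nnc(-c2ccc(-c3ccccc3)cc2)n1-c1cccc(COC)c1C`, is the next compound to be tested in this assay. It differs from compound 2 by methoxymethyl in place of hydrogen on an aromatic carbon. Within the data shown here, no measured pair in this set shows what such an addition on that ring does, so there is no precedent to lean on. The step from compound 2 to compound 3 is expected to be small, a 1.2-fold higher number from compound 2 to compound 3 (0.07 log units; within the scatter), with no confident direction. Compound 3 is therefore estimated to give 350 nM in this assay, within a range from 100 nM to 1200 nM.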

Compound 3, half-maximal inhibitory concentration: 2400 nM
Compound 3: the middle estimate sits 6.9-fold (0.84 log units) below what was measured; measured number above the stated range.
By their numbers in this assay, from the lowest: compound 2; then compound 3; then compound 1.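

In this assay, adding methoxymethyl in place of hydrogen on an aromatic carbon ortho to a methyl group gives an 8.0-fold higher number from compound 2 to compound 3 (0.90 log units; beyond the scatter) and so moves the number toward weaker inhibition. Among these compounds, this is the first change that can be read at a single place, and it shows that this position is not neutral: the addition costs measurable inhibition rather than passing unnoticed. No supporting data are available to explain the change.

From the compounds shown here alone, it remains open whether this loss belongs to methoxymethyl specifically or would follow any addition at this carbon, which a smaller group such as fluorine, a hydroxymethyl group or an aminomethyl group in the same place could help decide. Going by these compounds, it is also open whether the same addition would have a similar effect on the core of compound 1.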